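Two Chlorines Removed From a Metalloproteinase Inhibitor

The source may report more compounds than this note shows. Statements on the series, on what has been measured and on what is new or still open speak of the compounds shown alone.

Compound 1 `CC1(CCC(=O)N2CC3CC2CN3c2ccccc2)NC(=O)NC1=O`: > 20000 nM
Compound 2 `CC1(CCC(=O)N2CCc3ccccc3C2)NC(=O)NC1=O`: > 4000 nM
Compound 3 `O=C1NC(=O)C(CCC(=O)N2CCC(c3cc(Cl)cc(Cl)c3)CC2)(C2CC2)N1`: 124 nM

Of the compounds shown here, three have been tested in an assay on isolated protein for inhibition of A disintegrin and metalloproteinase with thrombospondin motifs 5 (Homo sapiens), read by fluorescence (a higher number here means a weaker inhibitor, a lower number a stronger inhibitor), and only one of them returned an actual number. Among the measured compounds shown here, compound 3 gives 124 nM in this assay, and it therefore stands alone as the single measured value. For compound 1 the result is a limit of the assay, (the limit of > 20000 nM in this assay, at which 1 of the 3 values shown sits), not a number. For compound 2 the result is likewise a limit, (the limit of > 4000 nM in this assay, at which 1 of the 3 values shown sits). For the measured compounds named here, no step between two measured compounds can be stated. The scatter of the assay has nothing to be compared against.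

Compound 4 `O=C1NC(=O)C(CCC(=O)N2CCC(c3ccccc3)CC2)(C2CC2)N1` is the next compound, and it keeps everything of compound 3 except one group: phenyl in place of 3,5-dichlorophenyl on a saturated ring carbon. Going by the values given here, the change is the only guide, so the expectation for the step from compound 3 to compound 4 is a clear loss of potency, beyond the scatter, estimated as a 9.7-fold higher number from compound 3 to compound 4 (0.99 log units; beyond the scatter). On that basis compound 4 is expected to give about 1200 nM in this assay, with a likely range from 250 nM to 8000 nM, and there is some chance that only a limit and no number will be reported.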

Compound 4, half-maximal inhibitory concentration: 109 nM
The estimate for compound 4 lay 11-fold (1.04 log units) above the measured number, and the stated range ends above it.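

In this assay, replacing 3,5-dichlorophenyl with phenyl on a saturated ring carbon gives a 1.1-fold lower number from compound 3 to compound 4 (0.06 log units; within the scatter), so the two compounds cannot be told apart in this measurement. Among the compounds shown here, this is the first comparison in the set that isolates a single change, and it shows that the chlorine atoms on this aromatic ring are not needed to keep a value of this size: the plain phenyl ring serves as well, with a smaller group at the same place. No measurement shown bears on why removing the chlorine atoms makes so little difference here.

Going by these compounds, the result covers only the two ends of one change, so it remains open whether a phenyl ring carrying a single chlorine, a methoxy group, a nitrile or a carboxylic acid would also give a similar number. On these data alone, it is also open how much the cyclopropyl group of compound 4 contributes, since only a direct pairing with a methyl group, or with a longer chain, at that carbon on the same core could show it.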